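A few compounds are considered here, and "the series" means these few. Any claim that something is new, unique, unknown or untested is made for them only; others in the source may bear on it.

In an ADME assay on microsomes from liver (Homo sapiens) for metabolic stability, with a stated time of 10 min (a lower number here means that less of the compound is left, a higher number that more of the compound is left), compound 1 (`CCC[C@]1(C(=O)N2CC[C@](c3ccc(C(F)(C(F)(F)F)C(F)(F)F)cc3)(S(=O)(=O)c3ccc(F)cc3)C2)CC[C@H](C(=O)O)CC1`) gives "not determined" (no result reported), and compound 2 (`O=C(O)C12CCC(C(=O)N3CC[C@](c4ccc(C(F)(C(F)(F)F)C(F)(F)F)cc4)(S(=O)(=O)c4ccc(F)cc4)C3)(CC1)C2`) gives "not determined" (no result reported). For the measured compounds named here, compound 3 (`O=C(O)C12CCC(C(=O)N3CC[C@](c4ccc(C(F)(C(F)(F)F)C(F)(F)F)cc4)(S(=O)(=O)c4ccc(F)cc4)C3)(CC1)CC2`) gives 100%, the only number in this small set, so it cannot be ranked against any neighbour. That reading means none of compound 3 was seen to disappear during the test.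

Compound 4 (`NC(=O)[C@H]1CC[C@H](C(=O)N2CC[C@](c3ccc(C(F)(C(F)(F)F)C(F)(F)F)cc3)(S(=O)(=O)c3ccc(F)cc3)C2)CC1`) keeps the shared core but exchanges the group on a carbonyl carbon whose other neighbours are an amide-type nitrogen in a ring: a group of 9 heavy atoms (7 carbon, 1 nitrogen, 1 oxygen; one six-membered non-aromatic ring of carbon only) in place of a group of 11 heavy atoms (9 carbon, 2 oxygen; 2 six-membered non-aromatic rings of carbon only), on a carbonyl carbon. The group that enters is 4-carbamoylcyclohexyl.

Going by the values given here, no measured pair shows what such an exchange does, so the expectation rests on compound 3 alone. With compound 3 at 100%, the scale leaves room only for a fall. A modest fall in this assay is expected, possibly none beyond the usual scatter, and the estimated change is a number 12 percentage points lower from compound 3 to compound 4 (beyond the scatter). For compound 4 the estimated value is 88%, with an expected range from 65% to 100%.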

Compound 4, percent of the compound remaining: 100%
Compound 4: the middle estimate sits 12 percentage points below what was measured; the range from low to high includes it.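

In this assay, the step to a 4-carbamoylcyclohexyl group on the carbonyl carbon gives no change at the digits printed from compound 3 to compound 4 (within the scatter), so this place in the molecule can take a group with one carbon-only ring instead of two without any visible loss in the read-out. Both compounds sit at the very top of the scale, which means this comparison can show that neither was seen to disappear, but cannot separate the two any further. Nothing measured here gives a reason for this result.

Going by these compounds, it remains open what a cyclohexyl group carrying an amine or a nitrile in place of the carbamoyl group would give in this assay. Also open, on these data alone, is whether an open-chain group on this carbonyl carbon would bring the reading down.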